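This account rests on a few compounds, and the source may have more. Where it says the series, first, only, none or still open, it means among the compounds named here.

Within the data shown here, in an in vitro ADME assay on microsomes from liver (Macaca mulatta) for metabolic stability, using NADPH, with a stated time of 10 min, tested at 0.5 uM (on this read-out lower numbers stand for a shorter-lived compound and higher numbers for a longer-lived compound), only two compounds with this core have been measured. Compound 1 `COc1cc(C2CCN(C[C@@H](C)O)CC2)ccc1Nc1ncc2ccc(-c3ccccc3N(C)S(C)(=O)=O)n2n1` gives < 0.0834 h, which is a limit of the assay and not a number. Compound 2 `COc1cc(C2CCN(CC(N)=O)CC2)ccc1Nc1ncc2ccc(-c3ccccc3N(C)S(C)(=O)=O)n2n1` gives < 0.0834 h, which is also a limit and not a number. The whole picture so far is the limit of < 0.0834 h in this assay, at which 2 of the 2 values shown sit, so compound 2 has no exact half-life to start from.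

Compound 3 `COc1cc(C2CCN(CC(N)=O)CC2)ccc1Nc1ncc2c(C)cc(-c3ccccc3N(C)S(C)(=O)=O)n2n1` differs from compound 2 in one place: methyl in place of hydrogen on an aromatic carbon. Among the measured compounds shown here, the only measured step is a step that the two limits leave unreadable from compound 1 to compound 2, and it concerns a different change, so it gives neither a size nor a direction for this one. With no measured support for a shift, the expected change is a step that the limit leaves unreadable from compound 2 to compound 3, which means no step beyond the scatter. For compound 3 the estimated half-life is 0.08 h, with an expected range from 0.04 h to 0.2 h.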

Compound 3, half-life: 0.1 h
Beside the measured number, compound 3's estimate is 1.3-fold (0.10 log units) below it, within the range that was stated.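

In this assay compound 3 gives 0.1 h, the first exact half-life among the compounds shown, so this aromatic carbon of the five-membered ring can carry a methyl with a value that can be read. Putting methyl in place of hydrogen there gives an at least 1.1-fold higher number from compound 2 to compound 3 (0.07 log units; that floor lies within the scatter). That figure is only a floor, and the real step could be larger, because compound 2 stands at a limit and not at a number: the limit of < 0.0834 h in this assay, at which 2 of the 3 values shown sit.

The step from compound 1 to compound 2 still cannot be read, so the two side chains on the saturated ring cannot be ranked. Also open, as far as these compounds go, are how an ethyl group or a chlorine atom at this same carbon would compare with methyl, and what the methyl would do alongside the 1-hydroxyethyl chain of compound 1.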